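Swapping a long sulfur-linked chain for a short one

This account rests on a few compounds, and the source may have more. Where it says the series, first, only, none or still open, it means among the compounds named here.

Four compounds share one core, differing only in the chain attached through sulfur and in the group on the ring nitrogen. In an ADME assay (MDM cells, Homo sapiens) for cytotoxicity, read by resazurin assay, with a stated time of 3 days (on this read-out lower numbers stand for stronger inhibition and higher numbers for weaker inhibition), compound 1 `C/C=C/Sc1nnc(COc2ccccc2C2=NOC(c3ccc(Cl)cc3Cl)C2)n1NC(=O)c1ccccc1` shows "not determined" (no result reported), with no result reported. In this assay compound 2 `CCOC(=O)CC(=O)CSc1nnc(COc2ccccc2C2=NOC(c3ccc(Cl)cc3Cl)C2)n1NC(C)=O` likewise shows "not determined" (no result reported), again with no result reported. For the measured compounds named here, the only measured member is compound 3 `CCCCSc1nnc(COc2ccccc2C2=NOC(c3ccc(Cl)cc3Cl)C2)n1NC(=O)c1ccccc1`, and in this assay compound 3 gives 2.5 ug/mL. Going by the values given here, compound 2 therefore stands without a value of its own, alongside compound 1 in the same position, so no comparison between measured compounds can be drawn from the set.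

The step from compound 2 leads to compound 4 `CCCSc1nnc(COc2ccccc2C2=NOC(c3ccc(Cl)cc3Cl)C2)n1NC(C)=O`. The change is ethyl in place of ((ethoxycarbonyl)methyl)carbonyl on a saturated chain carbon bound to a sulfur. Among the compounds with values here, with no measured pair available to show how such a change moves the read-out, the expectation rests on compound 3 alone. Since compound 3 gives 2.5 ug/mL with a related chain, a modest shift toward weaker inhibition, or none beyond the scatter, seems most likely. For compound 4 the value in this assay is estimated at 5 ug/mL, expected to fall between 1.5 ug/mL and 20 ug/mL.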

Compound 4, half-maximal inhibitory concentration: 128 ug/mL
Compound 4: the middle estimate sits 26-fold (1.41 log units) below what was measured, and the stated range ends below it.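

Compound 2 has no single value in this assay, so the step to compound 4 cannot be read. Going by these compounds, how ethyl in place of ((ethoxycarbonyl)methyl)carbonyl moves this read-out therefore stays open. No available evidence bears on the result for compound 4.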